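Isopropoxy in Place of Methyl on a Shared Core

The source may report more compounds than this note shows. Statements on the series, on what has been measured and on what is new or still open speak of the compounds shown alone.

Three compounds share one core and differ only in the group on one aromatic carbon. Compound 1 `O=c1c(-c2nn[nH]n2)c[nH]c2c(C(F)(F)F)cccc12` carries a trifluoromethyl group, compound 2 `CSc1cccc2c(=O)c(-c3nn[nH]n3)c[nH]c12` a methylsulfanyl group and compound 3 `Cc1cccc2c(=O)c(-c3nn[nH]n3)c[nH]c12` a methyl group. In a functional assay on the whole organism (strain Sprague-Dawley) for inhibition, with Rattus norvegicus as the target (a lower number here means that less compound is needed, a higher number that more compound is needed for the effect), compound 2 gives 25 mg/kg. For compound 1 the assay gives only a limit of > 25 mg/kg. For compound 3 it likewise reports only a limit of > 10 mg/kg, so compound 3 has no fixed place among the numbers shown. The steps between the measured compounds, a number no higher from compound 1 to compound 2 (the limit leaves the size open), a step that the two limits leave unreadable from compound 1 to compound 3 and a step that the limit leaves unreadable from compound 2 to compound 3, therefore cannot be sized. Compound 4 `CC(C)Oc1cccc2c(=O)c(-c3nn[nH]n3)c[nH]c12` differs from compound 3 in a single change: isopropoxy in place of methyl on an aromatic carbon. Among the measured compounds shown here, the nearest measured change, methylsulfanyl giving way to methyl, bears on it, but its size is not readable, and no measured step sets an expected size or direction for this change. Because compound 2 gives 25 mg/kg, compound 4 is expected at 25 mg/kg, with a range from 8 mg/kg to 80 mg/kg. The step this implies, a step that the limit leaves unreadable from compound 3 to compound 4, is expected to lie within the usual scatter.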

Compound 4, minimum effective dose: 1.25 mg/kg
The estimate for compound 4 lay 20-fold (1.30 log units) above the measured number; measured number outside the range, below it.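

Among the compounds shown here, at this position on the shared core, the group on the aromatic carbon can change the dose needed by far more than the usual scatter, and the first step here with a readable size is a 20-fold lower number from compound 2 to compound 4 (1.30 log units; beyond the scatter). Compound 3 has only a limit, which makes the methyl comparison, an at least 8.0-fold lower number from compound 3 to compound 4 (0.90 log units; beyond the scatter), a minimum size and not an exact one: the limit of > 10 mg/kg in this assay, at which 1 of the 4 values shown sits. Compound 1 also has only a limit, which likewise leaves the trifluoromethyl comparison, an at least 20-fold lower number from compound 1 to compound 4 (1.30 log units; beyond the scatter), as a minimum size: the limit of > 25 mg/kg in this assay, at which 1 of the 4 values shown sits.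

As far as these compounds go, what remains open is which part of isopropoxy matters, the oxygen attached to the aromatic carbon or the branched carbon chain, and comparing methoxy, ethoxy and plain isopropyl at the same place would help separate the two. The compounds shown also leave open how a longer chain such as butoxy, or a group of a different kind such as an amine or a carboxylic acid, would behave in this assay.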